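The compounds below may be only part of what the source reports. "The series", "measured", "known", "first", "only" and "open" are said of these compounds alone.

The measured compounds in a functional assay on MDA-MB-231 cells (Homo sapiens) for cytotoxicity, read by MTT assay, with a stated time of 48 h, in the presence of a further agent that is not named here; on this read-out lower numbers stand for stronger inhibition and higher numbers for weaker inhibition:
Compound 1 `COc1ccc2[nH]cc(-c3nc(C(=O)Nc4cc(OC)c(OC)c(OC)c4)cs3)c2c1` gives > 100000 nM, which is a limit of the assay.
Compound 2 `COc1cc(NC(=O)c2csc(-c3c[nH]c4ccc(Br)cc34)n2)cc(OC)c1OC` gives > 100000 nM, also a limit.
Compound 3 `O=C(NCc1ccccc1)c1csc(-c2c[nH]c3ccccc23)n1` gives > 100000 nM, again a limit.

Compound 2 therefore stands at the limit shared by every measured compound (the limit of > 100000 nM in this assay, at which 3 of the 3 values shown sit), and no number was reached for it. Compound 4 `COc1cc(NC(=O)c2csc(-c3c[nH]c4ccc(F)cc34)n2)cc(OC)c1OC` differs from it by fluoro in place of bromo on an aromatic carbon. Among the measured compounds shown here, the only measured step at a single place, a step that the two limits leave unreadable from compound 1 to compound 2, cannot be read because both of its ends sit at the limit (the limit of > 100000 nM in this assay, at which 3 of the 3 values shown sit), so it offers no guide to direction or size. Nothing measured speaks for the change to fluoro, and compound 4 is expected to stay at the limit too, the expected step being a number no higher from compound 2 to compound 4 (the limit leaves the size open). The estimate for compound 4 in this assay is 100000 nM, within 40000 nM to 300000 nM.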

Compound 4, half-maximal inhibitory concentration: > 100000 nM
Compound 4: no number, only a limit (the forecaster's own chance of this, stated with the estimate: 85%); the middle value sits exactly at the limit.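

The steps from compound 1 and compound 2 to compound 4 cannot be read, because each end of them is only a limit: the limit of > 100000 nM in this assay, at which 4 of the 4 values shown sit. The compounds shown leave open which change to the shared core, if any, would give a measurable number.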